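The compounds below may be only part of what the source reports. "The series", "measured", "known", "first", "only" and "open" are said of these compounds alone.

Compound 1, with the structure `COc1cc(N)c(Cl)cc1NC(=O)C1CCN(CC2CC2)CC1`, and compound 2, with the structure `COc1cc(N)c(Cl)cc1NC(=O)C1CCN(Cc2ccc(C)c(C)c2)CC1`, share the same core and differ only in the group on a saturated chain carbon bound to an amine nitrogen in a ring. In a functional assay on the whole organism for antagonist activity, with Mus musculus as the target (on this read-out lower numbers stand for an effect already at smaller amounts and higher numbers for an effect only at larger amounts of compound), compound 1 gives > 10 mg/kg, which is a limit of the assay rather than a number. In this assay compound 2 gives > 8 mg/kg, likewise a limit and not a number. For the measured compounds named here, compound 2 thus stands at a limit, and the one other value shown is a limit as well. The step that the two limits leave unreadable from compound 1 to compound 2 cannot be read, since both of its ends are limits, namely the limit of > 10 mg/kg in this assay, at which 1 of the 2 values shown sits, and (the limit of > 8 mg/kg in this assay, at which 1 of the 2 values shown sits). Compound 3, with the structure `COc1cc(N)c(Cl)cc1NC(=O)C1CCN(Cc2ccc(O)cc2)CC1`, arises from compound 2 by the change (4-hydroxyphenyl in place of 3,4-dimethylphenyl on a saturated chain carbon bound to an amine nitrogen in a ring). Going by the values given here, the only measured step bears on this kind of change but has no readable size, so there is no ground for expecting a shift in either direction beyond the scatter. Compound 3 is therefore expected to give 15 mg/kg, in the range 4 mg/kg to 60 mg/kg, with a real chance that only a limit is reported. That expectation amounts to the step that the limit leaves unreadable from compound 2 to compound 3.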

Compound 3, dose for half-maximal effect: > 8 mg/kg
Compound 3: no number, only a limit; the forecaster's own chance of this, stated with the estimate: 65%; the middle value does not contradict the limit.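

In this assay compound 3 gives > 8 mg/kg, a limit and not a number. The steps to compound 3 from compound 2 and from compound 1 therefore cannot be read. Compound 1, compound 2 and compound 3 leave open whether cyclopropyl, 3,4-dimethylphenyl or 4-hydroxyphenyl makes any difference to the dose for half-maximal effect.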